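A few compounds are considered here, and "the series" means these few. Any claim that something is new, unique, unknown or untested is made for them only; others in the source may bear on it.

Compound 1 `C=Cc1ccc(-c2cc(C)c3ncc(CSCCc4ccccc4)n3c2)cc1` gives 20 ug/mL in an ADME assay on HEL cells (Homo sapiens) for cytotoxicity, with a stated time of 3 days; on this read-out lower numbers stand for higher toxicity in this test and higher numbers for lower toxicity in this test.
Compound 2 `Cc1cc(-c2ccoc2)c2ncc(CSCCc3ccccc3)n2c1` gives 100 ug/mL in this assay.
Compound 3 `Cc1cc(N2CCN(C)CC2)c2ncc(CSCCc3ccccc3)n2c1` gives "not determined" (no result reported) in this assay.

In this assay compound 1 gives 20 ug/mL and compound 2 gives 100 ug/mL. Compound 3 has no result in this assay, so it stands nowhere on these numbers and offers no starting point. Compound 4 `Cc1cc(-n2ccnc2)c2ncc(CSCCc3ccccc3)n2c1` differs from compound 3 by 1H-imidazol-1-yl in place of 4-methylpiperazin-1-yl on an aromatic carbon. Among the measured compounds shown here, since no value for compound 3 exists and no step between measured compounds is known, the size and direction of this change in this assay cannot be read from the data, and neither a rise nor a fall is expected over the other. Compound 4 is therefore judged from compounds 1 and 2 alone, whose values lie apart. Compound 4 is expected to give about 60 ug/mL in this assay, with a range from 20 ug/mL to 100 ug/mL.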

Compound 4, minimum cytotoxic concentration: 20 ug/mL
Compound 4: the middle estimate sits 3.0-fold (0.48 log units) above what was measured, and the stated range covers the measured number.
By their numbers in this assay, from the lowest: compounds 1 and 4 (each within the scatter of the next); then compound 2.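

Placing 1H-imidazol-1-yl instead of furan-3-yl on this aromatic carbon gives a 5.0-fold lower number from compound 2 to compound 4 (0.70 log units; beyond the scatter) in this assay and so points to higher toxicity in this test, showing that the group at this position can move the read-out. The change from 4-methylpiperazin-1-yl cannot be read, since compound 3 has no result. Nothing shown bears on the reason for the step from furan-3-yl.

From the compounds shown here alone, how a carboxylic acid or a simple primary amine at this carbon would behave remains open. One step also cannot show whether other five-membered aromatic rings here, such as thiophene, would follow furan-3-yl or 1H-imidazol-1-yl.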